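Exchanging the bromo for a methyl on the phenoxy ring

The source may hold more compounds than are shown below. What is called first, only, known or untested is meant among the compounds shown, and "the series" means these compounds.

Three members of one series have been tested in a functional assay on HepG2 cells (Homo sapiens) for antiproliferative activity, read by MTT assay, with a stated time of 72 h; on this read-out higher numbers stand for weaker inhibition and lower numbers for stronger inhibition. Compound 1 `Cc1nn(C)c(Oc2ccc(F)cc2F)c1/C=N\CCCCCCOc1cc2oc(=O)cc(C)c2cc1Cl` gives only a limit, > 25000 nM. Compound 2 `Cc1nn(C)c(Oc2ccc(F)c(F)c2)c1/C=N\CCCCCCOc1cc2oc(=O)cc(C)c2cc1Cl` likewise gives only a limit, > 25000 nM. Among the measured compounds shown here, compound 3 `Cc1nn(C)c(Oc2ccccc2Br)c1/C=N\CCCCCCOc1cc2oc(=O)cc(C)c2cc1Cl` gives the single stated number of the set, 24200 nM, so compound 3 stands as the only compound with a readable value, while the two others sit at the limit of > 25000 nM in this assay, at which 2 of the 3 values shown sit. The measured steps to compound 3 are an at least 1.0-fold lower number from compound 1 to compound 3 (0.01 log units; that floor lies within the scatter) and an at least 1.0-fold lower number from compound 2 to compound 3 (0.01 log units; that floor lies within the scatter), and the step that the two limits leave unreadable from compound 1 to compound 2 cannot be read at all. Compound 4 `Cc1ccccc1Oc1c(/C=N\CCCCCCOc2cc3oc(=O)cc(C)c3cc2Cl)c(C)nn1C` is not yet measured; it differs from compound 3 by methyl in place of bromo on an aromatic carbon. Every measured change of the same ring has left the read-out at or very close to the limit, so the expected step is a 1.0-fold higher number from compound 3 to compound 4 (0.01 log units; within the scatter), which is no larger than the scatter and in no definite direction. Compound 4 is therefore estimated at 25000 nM in this assay, with a range from 12000 nM to 50000 nM.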

Compound 4, half-maximal inhibitory concentration: 7830 nM
Compound 4: the middle estimate sits 3.2-fold (0.50 log units) above what was measured; the whole stated range lies above it.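

Among the compounds shown here, exchanging bromo for methyl on an aromatic carbon ortho to a large group gives the first step in this assay that is printed as beyond the scatter: a 3.1-fold lower number from compound 3 to compound 4 (0.49 log units; beyond the scatter). For the compounds shown here, this position therefore responds to the exchange of one heavy atom for another, which the earlier compounds, all at or very close to the limit, could not show. The 2-methylphenyl group also stands apart from the 3,4-difluorophenyl and 2,4-difluorophenyl groups, with an at least 3.1-fold lower number from compound 2 to compound 4 (0.50 log units; beyond the scatter) and an at least 3.1-fold lower number from compound 1 to compound 4 (0.50 log units; beyond the scatter), but these two steps are only floors: the limit of > 25000 nM in this assay, at which 2 of the 4 values shown sit.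

This single pair gives no cause for the step and no rule for the position. On these data alone, whether an ethyl, a methoxy or a chloro on the same carbon would lower the number further remains open, as does whether the step would hold with a shorter chain.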